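This account rests on a few compounds, and the source may have more. Where it says the series, first, only, none or still open, it means among the compounds named here.

Measured compounds in an assay on cells for antagonist activity at transient receptor potential cation channel subfamily V member 1 (Homo sapiens), read by FLIPR and calcium flux, with a stated time of 6 min; a lower number here means a stronger inhibitor, a higher number a weaker inhibitor:
- compound 1 `CC(C(=O)NCc1ccc(C(C)(C)C)nc1N1CCCC1)c1ccc(NS(C)(=O)=O)c(F)c1` gives 1.2 nM
- compound 2 `CC(C)Oc1nc(C(C)(C)C)ccc1CNC(=O)C(C)c1ccc(NS(C)(=O)=O)c(F)c1` gives 2.3 nM
- compound 3 `CC(C(=O)NCc1ccc(C(C)(C)C)nc1OC1CCCC1)c1ccc(NS(C)(=O)=O)c(F)c1` gives 1.5 nM

Compound 1 holds the lowest of the three numbers, but neither of the other two is separated from it beyond the scatter: the step of a 1.3-fold higher number from compound 1 to compound 3 (0.10 log units; within the scatter) is the nearer one and the step of a 1.9-fold higher number from compound 1 to compound 2 (0.28 log units; within the scatter) the wider one. The two measured compounds also sit within the scatter of each other, as the step of a 1.5-fold lower number from compound 2 to compound 3 (0.19 log units; within the scatter) shows.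

Compound 4 `COCCCOc1nc(C(C)(C)C)ccc1CNC(=O)C(C)c1ccc(NS(C)(=O)=O)c(F)c1` has not yet been measured. It differs from compound 1 as follows: 3-methoxypropoxy in place of pyrrolidin-1-yl on an aromatic carbon. The two measured steps from compound 1 are the ones that bear on this change, since each also puts an alkoxy group in place of pyrrolidin-1-yl on the same aromatic carbon, and both stay within the scatter. A third alkoxy group at this position is therefore expected to behave alike in this assay: no step beyond the scatter, if anything a slightly higher number.

For compound 4 the expected value is 2 nM, within 0.8 nM to 5 nM, which amounts to an estimated step of a 1.7-fold higher number from compound 1 to compound 4 (0.22 log units; within the scatter).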

Compound 4, inhibition constant: 5.6 nM
Compound 4: the middle estimate sits 2.8-fold (0.45 log units) below what was measured; the measured number lies above the stated range.
By their numbers in this assay, from the lowest: compounds 1, 3 and 2 (each within the scatter of the next); then compound 4.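

In this assay, the position next to the ring nitrogen does not accept every alkoxy group equally: replacing pyrrolidin-1-yl with 3-methoxypropoxy gives a step beyond the scatter (a 4.7-fold higher number from compound 1 to compound 4 (0.67 log units; beyond the scatter)), which neither earlier alkoxy group did. The group on the oxygen also matters, since 3-methoxypropyl separates from both isopropyl (a 2.4-fold higher number from compound 2 to compound 4 (0.39 log units; beyond the scatter)) and cyclopentyl (a 3.7-fold higher number from compound 3 to compound 4 (0.57 log units; beyond the scatter)), though all three steps remain modest. No measurement shown here accounts for this loss.

Compound 4 combines a longer chain with an ether oxygen, so the two features cannot be separated here; a plain pentyloxy chain at this position would bear on that. From the compounds shown here alone, how an amine or a hydroxyl group at the end of the chain would read also remains open.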